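The source may hold more compounds than are shown below. What is called first, only, known or untested is meant among the compounds shown, and "the series" means these compounds.

Measured so far in an assay on HEK293 cells for positive allosteric modulation of metabotropic glutamate receptor 2 (Rattus norvegicus), read by thallium flux, with a stated time of 2.5 min; on this read-out higher numbers stand for an effect only at larger amounts of compound and lower numbers for an effect already at smaller amounts:

Compound 1 `Cc1c(OCCCCOc2ccc(C(=O)O)cc2)ccc(C(=O)CC2CCCC2)c1O` gives 824 nM.
Compound 2 `Cc1c(OCCCCOc2ccccc2C(=O)O)ccc(C(=O)CC2CCCC2)c1O` gives 335 nM.
Compound 3 `Cc1c(OCCCCOc2ccc(C(=O)O)c(Cl)c2)ccc(C(=O)CC2CCCC2)c1O` gives 510 nM.

Among these three numbers compound 3 stands second highest. Among the compounds with values here, the step of a 1.5-fold higher number from compound 2 to compound 3 (0.18 log units; within the scatter) and the step of a 1.6-fold lower number from compound 1 to compound 3 (0.21 log units; within the scatter) both stay within the scatter, so all three compounds sit close together, with only the step of a 2.5-fold lower number from compound 1 to compound 2 (0.39 log units; beyond the scatter) reaching beyond the scatter.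

Compound 4 `Cc1ccc(C(=O)O)cc1OCCCCOc1ccc(C(=O)CC2CCCC2)c(O)c1C` has not yet been measured. It differs from compound 3 in a single place: 5-carboxy-2-methylphenyl in place of 4-carboxy-3-chlorophenyl on an oxygen on a saturated carbon. Within the data shown here, two measured steps bear on this. The step of a 2.5-fold lower number from compound 1 to compound 2 (0.39 log units; beyond the scatter) shows that moving the carboxy group around the ring can shift the number modestly. The step of a 1.6-fold lower number from compound 1 to compound 3 (0.21 log units; within the scatter) shows that adding a chloro on that ring stays within the scatter; so its removal here, together with the new methyl, is not expected to matter much on its own. Since the carboxy in compound 4 takes yet another position, a small shift in either direction is possible, but nothing beyond the scatter is expected: a 1.1-fold lower number from compound 3 to compound 4 (0.05 log units; within the scatter). Compound 4 is therefore estimated at 450 nM, with a range from 200 nM to 1100 nM.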

Compound 4, half-maximal effective concentration: 1290 nM
Compound 4: middle estimate off by 2.9-fold (0.46 log units), on the low side; measured number above the stated range.
By their numbers in this assay, from the lowest: compounds 2, 3, 1 and 4 (each within the scatter of the next, the first and the last beyond it).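

In this assay, within the data shown here, the group on this oxygen turns out to span more than the earlier compounds showed: a 3.9-fold higher number from compound 2 to compound 4 (0.59 log units; beyond the scatter) is the largest step in the set, and a 2.5-fold higher number from compound 3 to compound 4 (0.40 log units; beyond the scatter) shows that replacing 4-carboxy-3-chlorophenyl with 5-carboxy-2-methylphenyl can also carry the number beyond the scatter. Earlier, only the move from 4-carboxyphenyl to 2-carboxyphenyl had done so, yet the new group does not separate clearly from the unsubstituted 4-carboxyphenyl group, since a 1.6-fold higher number from compound 1 to compound 4 (0.19 log units; within the scatter) stays within the scatter. No measurement at hand offers an explanation for these shifts.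

The change from compound 3 to compound 4 moves the carboxy group and trades chloro for methyl in a single step, so these compounds cannot show how much each part contributes. They also leave open how this position would respond to a tetrazole or an amide in place of the carboxylic acid, or to a longer chain between the two oxygens.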